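A small swap on a sulfonyl sulfur

The source may report more compounds than this note shows. Statements on the series, on what has been measured and on what is new or still open speak of the compounds shown alone.

In a physicochemical assay for solubility, measured as kinetic solubility (a lower number here means a less soluble compound, a higher number a more soluble compound), compound 1 (`Cc1cnc(NC(=O)c2cc(Oc3cnc(C(=O)N(C)C)cn3)c3cc(C)nn3c2)cn1`) gives 123000 nM as its reading. Compound 2 (`Cc1cnc(NC(=O)c2cc(Oc3ccc(C(=O)N(C)C)cc3)c3cn(C)nc3c2)cn1`) gives 351000 nM and compound 3 (`Cc1cnc(NC(=O)c2cc(Oc3ccc(S(C)(=O)=O)cc3)c3cn(C)nc3c2)cn1`) gives 454000 nM on the same scale. Compound 3 therefore sits level with compound 2 within the scatter, while compound 1 lies beyond the scatter from it.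

Compound 4 (`Cc1cnc(NC(=O)c2cc(Oc3ccc(S(=O)(=O)N(C)C)cc3)c3cn(C)nc3c2)cn1`) is not yet measured. Its structure differs from compound 3 as follows: dimethylamino in place of methyl on a sulfonyl sulfur (dimethylamino in place of methyl on a sulfonyl sulfur, or methylsulfonyl to dimethylsulfamoyl). For the measured compounds named here, no measured pair shows this exact change. The closest evidence is the swap of dimethylcarbamoyl for methylsulfonyl on an aromatic carbon, which gave a 1.3-fold higher number from compound 2 to compound 3 (0.11 log units; within the scatter) in this assay and so stayed small. One small step is thin evidence, so the range stays wide. The estimate is a 1.5-fold lower number from compound 3 to compound 4 (0.18 log units; within the scatter) as the expected step, meaning no expected change beyond the scatter. For compound 4 an estimated 300000 nM is expected, with a range of 130000 nM to 600000 nM around it.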

Compound 4, solubility: 134000 nM
Beside the measured number, compound 4's estimate is 2.2-fold (0.35 log units) above it, within the range that was stated.
By their numbers in this assay, from the lowest: compounds 1 and 4 (each within the scatter of the next); then compounds 2 and 3 (each within the scatter of the next).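

On a sulfonyl sulfur, dimethylamino in place of methyl is a real change in this assay and gives a 3.4-fold lower number from compound 3 to compound 4 (0.53 log units; beyond the scatter) here. The earlier swap on the aromatic carbon gave only a 1.3-fold higher number from compound 2 to compound 3 (0.11 log units; within the scatter) and so left dimethylcarbamoyl and methylsulfonyl level, but dimethylsulfamoyl stands apart from dimethylcarbamoyl too, with a 2.6-fold lower number from compound 2 to compound 4 (0.42 log units; beyond the scatter) as the reading for that swap. Nothing in the data given explains why this group lowers the number.

The compounds shown leave open whether an unsubstituted amino group or a morpholine on the same sulfonyl sulfur would read like compound 3 or like compound 4. They also cannot tell whether the step would carry over to the core of compound 1, which differs from compound 2 in more than one place.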